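This account rests on a few compounds, and the source may have more. Where it says the series, first, only, none or still open, it means among the compounds named here.

Compound 1 `O=C(NO)c1cccc(-c2cn([C@@H]3C[C@@H](CO)N(CCCc4ccccc4)C3)nn2)c1` carries a 3-(hydroxycarbamoyl)phenyl on the shared core. In an assay on Sf9 cells for inhibition of histone deacetylase 11 (Homo sapiens), read by fluorescence, tested at 0.5 uM (a lower number here means less inhibition, a higher number more inhibition at the concentration tested (going by the name of the read-out)), compound 1 gives < 10%, which is a limit of the assay and not a number. Compound 2 `O=C(/C=C/c1cn([C@@H]2C[C@@H](CO)N(CCCc3ccccc3)C2)nn1)NO` differs from compound 1 by 2-(hydroxycarbamoyl)ethenyl in place of 3-(hydroxycarbamoyl)phenyl on an aromatic carbon. In this assay compound 2 gives 13%. The step of a number at least 3 percentage points higher from compound 1 to compound 2 (that floor lies within the scatter) is therefore small; its floor rests on (the limit of < 10% in this assay, at which 2 of the 3 values shown sit).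

Compound 3 `O=C(NO)c1cccc(-c2cn([C@H]3C[C@@H](C(=O)O)N(CCCc4ccccc4)C3)nn2)c1` has a core that differs from that of compound 1; the difference between the two cores is not broken down here. In this assay compound 3 gives < 10%, a limit of the assay and not a number.

Compound 4 `O=C(/C=C/c1cn([C@H]2C[C@@H](C(=O)O)N(CCCc3ccccc3)C2)nn1)NO` is not yet measured. It stands to compound 3 as compound 2 stands to compound 1: 2-(hydroxycarbamoyl)ethenyl in place of 3-(hydroxycarbamoyl)phenyl on an aromatic carbon, the same change at the same place. The step is expected to follow the measured one, a number at least 2 percentage points higher from compound 3 to compound 4 (that floor lies within the scatter), resting on the measured step of a number at least 3 percentage points higher from compound 1 to compound 2 (that floor lies within the scatter). On that basis compound 4 is estimated at 12% in this assay, with a likely span from 5% to 20%, and a fair chance that only a limit is reported.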

Compound 4, a percentage reported as inhibition, at one concentration (the size of the read-out at that concentration, not a potency): 29%
Estimate against measurement, compound 4: 17 percentage points below, outside the stated range (above it).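

In this assay, 2-(hydroxycarbamoyl)ethenyl in place of 3-(hydroxycarbamoyl)phenyl gives a number at least 19 percentage points higher from compound 3 to compound 4 (beyond the scatter), so on the core of compound 3 the change brings a real gain in inhibition at the concentration tested. Set beside the same change on the core of compound 1, this does not show that the size of the step depends on the core: the same change on two cores in this assay, a number at least 3 percentage points higher (that floor lies within the scatter) from compound 1 to compound 2 and a number at least 19 percentage points higher (beyond the scatter) from compound 3 to compound 4; the limit leaves it open whether they differ. Both steps start from a limit and so give only floors, leaving their true sizes unknown: the limit of < 10% in this assay, at which 2 of the 4 values shown sit.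

Which part of the difference between the two cores goes with the larger floor stays open, as does the outcome of this change on a core carrying an ester or an amide in place of the carboxylic acid. Also open, going by these compounds, is whether a longer chain bearing the hydroxycarbamoyl group, in place of 2-(hydroxycarbamoyl)ethenyl, would carry across both cores in the same way.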